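A few compounds are considered here, and "the series" means these few. Any claim that something is new, unique, unknown or untested is made for them only; others in the source may bear on it.

Measured in a functional assay on BT-474 cells (Homo sapiens) for antiproliferative activity, read by MTT assay, with a stated time of 72 h; a higher number here means a weaker inhibitor, a lower number a stronger inhibitor:
compound 1 `CC(Nc1ncnc2ccc(-c3cnn(C4CCNCC4)c3)cc12)c1c(Cl)ccc(F)c1Cl` gives 8130 nM
compound 2 `CC(Nc1nc(N)nc2ccc(-c3cnn(C4CCNCC4)c3)cc12)c1c(Cl)ccc(F)c1Cl` gives 5100 nM

Compound 2 stands within the scatter of compound 1, with a 1.6-fold lower number from compound 1 to compound 2 (0.20 log units; within the scatter) for amino in place of hydrogen on an aromatic carbon. Compound 3 `CC(Nc1nc(N)nc2ccc(-c3cnn(C)c3)cc12)c1c(Cl)ccc(F)c1Cl` differs from compound 2 by methyl in place of piperidin-4-yl on an aromatic nitrogen. Within the data shown here, the one measured step lies at another place on the core, so no measured step covers this change. In this assay the step of a 1.1-fold higher number from compound 2 to compound 3 (0.03 log units; within the scatter) is expected to stay within the scatter, with no direction favoured. For compound 3 the estimate is 5500 nM with an expected range from 2000 nM to 18000 nM for this wide uncertainty.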

Compound 3, half-maximal inhibitory concentration: 7120 nM
Beside the measured number, compound 3's estimate is 1.3-fold (0.11 log units) below it; the range from low to high includes it.
By their numbers in this assay, from the lowest: compounds 2, 3 and 1 (each within the scatter of the next).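

On the aromatic nitrogen of the five-membered ring, methyl in place of piperidin-4-yl gives a 1.4-fold higher number from compound 2 to compound 3 (0.14 log units; within the scatter) in this assay and so stays within the scatter. Among these compounds, removing the six-membered non-aromatic ring therefore leaves this read-out unresolved from compound 2, a first reading at this position, whereas the earlier step concerned another place on the core. Nothing available bears on the reason for this result.

As far as these compounds go, whether a 2-hydroxyethyl chain or a carboxylic acid on this nitrogen would move the number beyond the scatter remains open.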